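Nitrofuran amides on Vero cells: one change, two settings

The source may report more compounds than this note shows. Statements on the series, on what has been measured and on what is new or still open speak of the compounds shown alone.

Compound 1 `O=C(NCc1ccc(Oc2ccc(Cl)cc2)cc1)c1ccc([N+](=O)[O-])o1` — 8400 nM
Compound 2 `O=C(NCc1ccc(COc2ccc(Cl)cc2)cc1)c1ccc([N+](=O)[O-])o1` — 4000 nM
Compound 3 `CC(C)(NC(=O)c1ccc([N+](=O)[O-])o1)c1ccc(Oc2ccc(Cl)cc2)cc1` — 67000 nM

Of the compounds shown here, three have been measured in an ADME assay on Vero cells (Chlorocebus sabaeus) for cytotoxicity, read by MTT assay, with a stated time of 48 h; a higher number here means that more compound is tolerated, a lower number that less compound is tolerated. Compound 1 gives 8400 nM in this assay, compound 2 gives 4000 nM, and compound 3 gives 67000 nM, the highest of the three numbers. Compounds 1 and 2 differ in one place, ((4-chlorophenoxy)methyl in place of 4-chlorophenoxy on an aromatic carbon), and this step gave a 2.1-fold lower number from compound 1 to compound 2 (0.32 log units; beyond the scatter). The difference between the core of compound 1 and the core of compound 3 is not broken down here.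

Compound 4 `CC(C)(NC(=O)c1ccc([N+](=O)[O-])o1)c1ccc(COc2ccc(Cl)cc2)cc1` is not yet measured. It differs from compound 3 by (4-chlorophenoxy)methyl in place of 4-chlorophenoxy on an aromatic carbon, the same change that turns compound 1 into compound 2, made at the same place. If the change acts on the core of compound 3 as it did on compound 1, a step of similar size is expected, so compound 4 is expected to give a value of a 2.1-fold lower number from compound 3 to compound 4 (0.32 log units; beyond the scatter) relative to compound 3, resting on the step of a 2.1-fold lower number from compound 1 to compound 2 (0.32 log units; beyond the scatter). Compound 4 is therefore estimated at 32000 nM in this assay, with a likely range from 14000 nM to 70000 nM.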

Compound 4, half-maximal cytotoxic concentration: 120000 nM
For compound 4 the middle estimate is 3.8-fold (0.57 log units) below the measured one; the measured number lies above the stated range.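

On the core of compound 3, (4-chlorophenoxy)methyl in place of 4-chlorophenoxy gave a 1.8-fold higher number from compound 3 to compound 4 (0.25 log units; within the scatter) in this assay, a step that cannot be told apart from repeat measurement. Read beside the earlier step, the change did not carry over from one core to the other with the size it had on the core of compound 1: the same change on two cores in this assay, a 2.1-fold lower number (0.32 log units; beyond the scatter) from compound 1 to compound 2 and a 1.8-fold higher number (0.25 log units; within the scatter) from compound 3 to compound 4, 3.8-fold (0.58 log units) apart, beyond the scatter of two such steps This rests on a single pair of compounds for each core, so it shows that the step cannot be assumed to transfer within this series, but it gives no reason for the gap and no rule for predicting the step on any further core.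

The compounds shown leave open how this change would behave on a third core, for example one carrying an amine or a carboxylic acid. They also leave open whether a longer chain in place of the (4-chlorophenoxy)methyl group would follow either of the two cores.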